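The compounds below may be only part of what the source reports. "The series", "measured", "known", "first", "only" and "open" are said of these compounds alone.

Measured compounds:
Compound 1 `CCN1CCN(CCCn2cnc3c(N4CCN(CC)CC4)nc(NCc4ccccc4)nc32)CC1` — 140 nM
Compound 2 `CN(C)Cc1ccc(CNc2nc(N3CCN(C4CCCC4)CC3)c3ncn(CCCN4CCCC4)c3n2)cc1` — 7 nM
Compound 3 `CCN1CCN(c2nc(NCc3ccc(CN(C)C)cc3)nc3c2ncn3CCCN2CCCC2)CC1` — 90 nM

In an assay on HEK293 cells for antagonist activity at Toll-like receptor 9 (Homo sapiens), read by spectrophotometry (on this read-out higher numbers stand for weaker inhibition and lower numbers for stronger inhibition), compound 2 gives 7 nM, the lowest number of the three: compound 3 sits at 90 nM and compound 1 at 140 nM. Going by the values given here, the one single-site step measured so far, a 13-fold higher number from compound 2 to compound 3 (1.11 log units; beyond the scatter), shows that a change at a ring amine nitrogen on this core moves the read-out by a large amount.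

Compound 4 `Nc1nc(N2CCN(C3CCCC3)CC2)c2ncn(CCCN3CCCC3)c2n1` is the unmeasured partner of compound 2. The change is hydrogen in place of 4-((dimethylamino)methyl)benzyl on a nitrogen on an aromatic ring, that is, the whole benzylamine substituent is cut back to a bare amino group. Among the compounds with values here, no measured step touches this position; compounds 1 and 3 both keep a benzyl-type group there, so the recorded values show nothing directly about its removal. Within the data shown here, the account therefore rests on the size of the one measured step and on the fact that a substantial group is lost. The expectation is a large step upward, with wide uncertainty.

For compound 4 the estimated value in this assay is 250 nM, within a range of 40 nM to 1600 nM, which means an expected step of a 36-fold higher number from compound 2 to compound 4 (1.55 log units; beyond the scatter).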

Compound 4, half-maximal inhibitory concentration: 120 nM
Beside the measured number, compound 4's estimate is 2.1-fold (0.32 log units) above it; the measured number falls inside the stated range.
By their numbers in this assay, from the lowest: compound 2; then compounds 3, 4 and 1 (each within the scatter of the next).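

Going by these compounds alone, compound 4 is the first direct reading at this position: cutting (4-((dimethylamino)methyl)benzyl)amino back to amino gives a 17-fold higher number from compound 2 to compound 4 (1.23 log units; beyond the scatter) in this assay, so this substituent on the aromatic ring nitrogen, not only the ring amine nitrogen probed earlier, weighs heavily on the read-out. The bare amino compound 4 still gives 120 nM, so the loss of all of the group's heavy atoms leaves a measurable inhibition. Nothing available explains the size of this step.

It remains open which part of the group accounts for the step: a plain benzyl or a methyl on this nitrogen, or a carboxylic acid in place of the dimethylamino group, would help to separate the contributions. Also open, as far as these compounds go, is whether the same cut would give a similar step with ethyl in place of cyclopentyl.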